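The source may report more compounds than this note shows. Statements on the series, on what has been measured and on what is new or still open speak of the compounds shown alone.

In a functional assay on MKN-45 cells (Homo sapiens) for cytotoxicity, read by MTT assay, with a stated time of 48 h (a higher number here means a weaker inhibitor, a lower number a stronger inhibitor), compound 2 `CCc1nnc(SCC(=O)c2ccc(Cl)cc2)n1N1C(=O)c2ccccc2C1=O` gives only a limit of the test, > 200000 nM. Compound 1 `CSc1nnc(C)n1N1C(=O)c2ccccc2C1=O`, which shares the same core, likewise gives only a limit in this assay, namely > 200000 nM. Both readings thus sit at the same edge, (the limit of > 200000 nM in this assay, at which 2 of the 2 values shown sit). Compound 3 `CCc1nnc(SC)n1N1C(=O)c2ccccc2C1=O` differs from compound 2 by hydrogen in place of (4-chlorophenyl)carbonyl on a saturated chain carbon bound to a sulfur. Neither measured compound reaches a number, so no step beyond the scatter is expected, a step that the limit leaves unreadable from compound 2 to compound 3. For compound 3 the expected outcome in this assay is again a limit rather than a number, estimated at 300000 nM with a range from 150000 nM to 1000000 nM.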

Compound 3, half-maximal inhibitory concentration: > 200000 nM
Compound 3 gave a limit, no number (the forecaster's own chance of this, stated with the estimate: 90%); the middle value does not contradict the limit.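

Compound 1, compound 2 and compound 3 all stop at the edge of the test, so no step between them can be read: the limit of > 200000 nM in this assay, at which 3 of the 3 values shown sit.

The compounds shown leave open whether any change to the shared core gives a measurable number in this assay.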